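A few compounds are considered here, and "the series" means these few. Any claim that something is new, unique, unknown or untested is made for them only; others in the source may bear on it.

Measured so far in an assay on HEK293 cells for positive allosteric modulation of metabotropic glutamate receptor 5 (Homo sapiens), read by FLIPR; a higher number here means that more compound is needed for the effect, a lower number that less compound is needed:
compound 1 `O=C(C1CCC(F)(F)CC1)N1CC(c2nc(-c3cccc(Cl)c3)no2)C1`, 180 nM
compound 2 `O=C(c1cccc(F)c1)N1CC(c2nc(-c3cccc(Cl)c3)no2)C1`, only the limit > 10000 nM
compound 3 `Cc1cccc(-c2noc(C3CN(C(=O)c4cccc(F)c4)C3)n2)c1`, only the limit > 10000 nM

Compound 2 stands at the limit of this assay, not at a number; of the three values two sit there (the limit of > 10000 nM in this assay, at which 2 of the 3 values shown sit). Compound 4 `O=C(N1CCCCCC1)N1CC(c2nc(-c3cccc(Cl)c3)no2)C1` differs from compound 2 by azepan-1-yl in place of 3-fluorophenyl on a carbonyl carbon. Among the measured compounds shown here, the one step that bears on this change is an at least 55-fold higher number from compound 1 to compound 2 (1.74 log units; beyond the scatter), where a six-membered aromatic ring on the carbonyl replaced a non-aromatic ring and lost everything; compound 4 moves back to a non-aromatic ring on that carbon. The step that the two limits leave unreadable from compound 2 to compound 3 tells nothing usable. A large drop in the number is therefore expected, an at least 16-fold lower number from compound 2 to compound 4 (1.22 log units; beyond the scatter), with a real chance that only a limit is again returned. Compound 4 is estimated at 600 nM, range 100 nM to 6000 nM.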

Compound 4, half-maximal effective concentration: 47 nM
Beside the measured number, compound 4's estimate is 13-fold (1.11 log units) above it, outside the stated range (below it).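

In this assay, azepan-1-yl on the carbonyl carbon gives an at least 210-fold lower number from compound 2 to compound 4 (2.32 log units; beyond the scatter), so the response absent with 3-fluorophenyl returns. Compound 2 gives only a limit, so that step is a bound and not a measured size: the limit of > 10000 nM in this assay, at which 2 of the 4 values shown sit. Azepan-1-yl also improves on 4,4-difluorocyclohexyl, with a 3.8-fold lower number from compound 1 to compound 4 (0.58 log units; beyond the scatter), so this carbonyl carbon takes a ring attached through nitrogen as well as one attached through carbon.

Ring size, the ring nitrogen and the loss of fluorine all change together in that last step, and the compounds shown do not separate them. On these data alone, how a piperidin-1-yl, a morpholin-4-yl or an open-chain diethylamino group would read at this position remains open.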